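Methyl at the benzoyl ring: a small step expected

The compounds below may be only part of what the source reports. "The series", "measured", "known", "first", "only" and "open" are said of these compounds alone.

Three compounds share one core and differ only in the benzoyl ring. Compound 1 `COc1cc2ncnc(NNC(=S)NC(=O)c3ccc(Cl)cc3)c2cc1OC` gives 7530 nM in a functional assay on CNE-2 cells (Homo sapiens) for cytotoxicity, read by MTT assay, with a stated time of 72 h; on this read-out lower numbers stand for stronger inhibition and higher numbers for weaker inhibition. Compound 2 `COc1cc2ncnc(NNC(=S)NC(=O)c3cccc(Cl)c3)c2cc1OC` gives 7460 nM in the same assay, and compound 3 `COc1cc2ncnc(NNC(=S)NC(=O)c3ccccc3)c2cc1OC` gives 8180 nM. Compound 3 carries the highest of the three numbers, but the steps of a 1.1-fold higher number from compound 1 to compound 3 (0.04 log units; within the scatter) and a 1.1-fold higher number from compound 2 to compound 3 (0.04 log units; within the scatter) both lie within the scatter, as does the step of a 1.0-fold lower number from compound 1 to compound 2 (0.00 log units; within the scatter).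

Compound 4 `COc1cc2ncnc(NNC(=S)NC(=O)c3ccccc3C)c2cc1OC` is not yet measured. It differs from compound 3 by methyl in place of hydrogen on an aromatic carbon, a methyl on the aromatic carbon ortho to a large group. The two steps that remove a chloro from that same ring bear most on this change, and neither moved the number beyond the scatter. A methyl in place of hydrogen is therefore expected to give a step of a 1.1-fold lower number from compound 3 to compound 4 (0.04 log units; within the scatter), with no direction beyond the scatter. Compound 4 is estimated at 7500 nM, in a range from 3500 nM to 16000 nM.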

Compound 4, half-maximal inhibitory concentration: 10500 nM
Compound 4: middle estimate off by 1.4-fold (0.15 log units), on the low side; measured number inside the range.
By their numbers in this assay, from the lowest: compounds 2, 1, 3 and 4 (each within the scatter of the next).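

Within the data shown here, with compound 4 the ring carries a methyl for the first time in this set, on the aromatic carbon ortho to a large group, and in this assay this change gives a 1.3-fold higher number from compound 3 to compound 4 (0.11 log units; within the scatter), which stays within the scatter. Exchanging the whole ring gives the same picture, with a 1.4-fold higher number from compound 2 to compound 4 (0.15 log units; within the scatter) and a 1.4-fold higher number from compound 1 to compound 4 (0.14 log units; within the scatter), so in this assay 2-methylphenyl cannot be told apart from 3-chlorophenyl or 4-chlorophenyl on the carbonyl carbon. Nothing available here explains why these four numbers lie so close together.

From the compounds shown here alone, it remains open whether any group on this ring can move the number beyond the scatter. An amine, a carboxylic acid or a longer chain on the same carbon would test this, as would a change to the shared core.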